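The source may hold more compounds than are shown below. What is called first, only, known or untested is meant among the compounds shown, and "the series" means these compounds.

Measured compounds:

Compound 1, `Cc1c(C)c2c(c(C)c1O)CCC(C)(C(=O)NCCS)O2`, gives 92% in a functional assay, with a stated time of 30 min, tested at 100 uM; a higher number here means a stronger effect of the compound at the concentration tested, a lower number a weaker effect.
Compound 2, `CCOC(=O)C(CS)NC(=O)/C=C/c1cc(C(C)(C)C)c(O)c(C(C)(C)C)c1`, gives 70% in this assay.
Compound 3, `CC(C)(C)c1cc(C(=O)NCCS)cc(C(C)(C)C)c1O`, gives 45% in this assay.

Among these three numbers compound 2 stands second highest. Its nearest neighbour is compound 1, whose number lies higher by a margin beyond the usual scatter of this kind of measurement, and its furthest is compound 3, whose number lies lower, again beyond the scatter. So compound 2 sits between a clearly stronger and a clearly weaker compound.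

The step under consideration leads from compound 2 to compound 4, `CC(C)(C)c1cc(/C=C/C(=O)NCCS)cc(C(C)(C)C)c1O`, which has not yet been measured in this assay. The structural change is:

hydrogen in place of ethoxycarbonyl on a saturated chain carbon bound to an amide-type nitrogen and a saturated chain carbon

Among the measured compounds shown here, no pair of measured compounds differs in exactly this way, so the size of the step cannot be read from a measured example. Compound 4 keeps everything else of compound 2 and now carries the same 2-sulfanylethyl amide chain as compound 1 and compound 3, whose numbers lie far apart from each other. Given that spread, a step from compound 2 to compound 4 of no more than the scatter is expected, with a number 5 percentage points lower from compound 2 to compound 4 (within the scatter) as the estimated change. Compound 4 is therefore expected to give about 65%, within a range from 45% to 85%.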

Compound 4, a percentage reported as activity, at one concentration (the size of the read-out at that concentration, not a potency): 60%
Beside the measured number, compound 4's estimate is 5 percentage points above it, within the range that was stated.
By their numbers in this assay, from the lowest: compound 3; then compounds 4 and 2 (each within the scatter of the next); then compound 1.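

Replacing ethoxycarbonyl with hydrogen on a saturated chain carbon bound to an amide-type nitrogen and a saturated chain carbon gives, in this assay, a number 10 percentage points lower from compound 2 to compound 4 (within the scatter), so the two numbers cannot be told apart. Among the compounds shown here, this is the first measured example of a change at this position, and it shows that the read-out stays within the scatter when all 5 heavy atoms of the ethoxycarbonyl group are lost: on this shared core, the 1-(ethoxycarbonyl)-2-sulfanylethyl and 2-sulfanylethyl chains perform alike at the one concentration tested. No measurement of any other property accompanies these compounds, so the result comes with no explanation.

Only hydrogen and ethoxycarbonyl are shown on this carbon, so it remains open whether a carboxylic acid, a methyl group or a longer ester there would also stay within the scatter or move the number clearly. From the compounds shown here alone, because the read-out comes from a single concentration, it also remains open whether compound 2 and compound 4 would still match at other concentrations.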